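The source may report more compounds than this note shows. Statements on the series, on what has been measured and on what is new or still open speak of the compounds shown alone.

Compound 1 `COc1cc(/C=C/C(=O)c2cccc(-n3cc(-c4ccc(Cl)cc4)[nH]c3=O)c2)ccc1O` gives 3090 nM in a functional assay on T47D cells (Homo sapiens) for inhibition; on this read-out higher numbers stand for weaker inhibition of growth and lower numbers for stronger inhibition of growth.
Compound 2 `COc1cc(/C=C/C(=O)c2cccc(-n3cc(-c4ccccc4)[nH]c3=O)c2)cc(OC)c1OC` gives 2190 nM in this assay.

Compound 1 and compound 2 give numbers that sit within the usual scatter of each other, so neither stands apart on this read-out. Compound 3 `COc1cc(/C=C/C(=O)c2cccc(-n3cc(-c4ccccc4)[nH]c3=O)c2)ccc1O` has not yet been measured. It differs from compound 1 by hydrogen in place of chloro on an aromatic carbon. Among the measured compounds shown here, no measured pair shows this change directly, so only a small shift is expected in this assay, none beyond the scatter in either direction. The estimate for compound 3 in this assay is 3000 nM, expected to fall between 1200 nM and 8000 nM. The expected step is a 1.0-fold lower number from compound 1 to compound 3 (0.01 log units; within the scatter).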

Compound 3, concentration for 50% growth inhibition: 2700 nM
For compound 3 the middle estimate is 1.1-fold (0.05 log units) above the measured one, and the stated range covers the measured number.
By their numbers in this assay, from the lowest: compounds 2, 3 and 1 (each within the scatter of the next).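

In this assay the change from 4-chlorophenyl to phenyl gives a 1.1-fold lower number from compound 1 to compound 3 (0.06 log units; within the scatter) so removing this chloro group makes no readable difference to growth inhibition. Among the compounds shown here, compounds 1 and 3 are the first pair here that differ in only one place, which lets this position be judged directly. No other measurement is available that could explain this result.

Only chloro and hydrogen appear at this position on the ring. As far as these compounds go, whether an amine or a carboxylic acid there would shift the number beyond the scatter remains open.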